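Swapping an aryl group for pyrrolidinyl on a quinazoline scaffold

The source may hold more compounds than are shown below. What is called first, only, known or untested is meant among the compounds shown, and "the series" means these compounds.

Measured compounds:
compound 1, `FC(F)(F)c1ccccc1-c1nc(NCc2ccc(-c3ccncc3)cc2)c2ccccc2n1`, 1900 nM
compound 2, `FC(F)(F)c1ccc(-c2nc(NCc3ccc(-c4cccnc4)cc3)c3ccccc3n2)cc1`, "not active" (no number reported)

In an assay on a protein complex for inhibition of ubiquitin carboxyl-terminal hydrolase 1/WD repeat-containing protein 48 (Homo sapiens), read by fluorescence (on this read-out higher numbers stand for weaker inhibition and lower numbers for stronger inhibition), compound 1 gives 1900 nM. In this assay compound 2 is reported as "not active" (no number reported), with no number attached, so compound 2 stands without a value on the scale on which compound 1 is placed. Among the compounds with values here, compound 1 and compound 2 differ in more than one place, so their two values show only that one of the pair has a measurable number and the other does not.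

Compound 3, `c1cncc(-c2ccc(CNc3nc(N4CCCC4)nc4ccccc34)cc2)c1`, is not yet measured. It differs from compound 2 in one place: pyrrolidin-1-yl in place of 4-(trifluoromethyl)phenyl on an aromatic carbon. Within the data shown here, no step between measured compounds is available to calibrate this change, and compound 2 itself offers no number from which a step could be counted. The most that can be said is that compound 3 carries a group of a different kind at that position, and whether this returns a measurable inhibition is open; the expectation is a number at the weak end rather than none at all, but with wide uncertainty. Compound 3 is estimated at 3000 nM in this assay, expected to fall within 500 nM to 20000 nM.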

Compound 3, half-maximal inhibitory concentration: "not active" (no number reported)
Compound 3: no number reported; the estimate stays without a comparison.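

In this assay compound 2 and compound 3 both stand without a number, so no step can be read between them. The compounds shown leave open whether pyrrolidin-1-yl or 4-(trifluoromethyl)phenyl at this position makes any measurable difference to inhibition. Nothing shown offers an explanation for the result of compound 3.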